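A few compounds are considered here, and "the series" means these few. Any claim that something is new, unique, unknown or untested is made for them only; others in the source may bear on it.

In a functional assay, read by spectrophotometry, with a stated time of 2 h (on this read-out lower numbers stand for stronger inhibition and higher numbers for weaker inhibition), compound 1 `CC(C)[C@@H]1CC[C@@H](C)C[C@@]12N(C)C(=O)[C@@H]1[C@H]3C(=O)NC(=O)[C@H]3ON12` gives 1500 ug/mL. Compound 2 `Cc1ccc(N2C(=O)[C@H]3[C@H](ON4[C@@H]3C(=O)N(C)[C@@]43C[C@H](C)CC[C@H]3C(C)C)C2=O)c(C)c1` gives 420 ug/mL, the lowest of the two numbers, and the step of a 3.6-fold lower number from compound 1 to compound 2 (0.55 log units; beyond the scatter) shows that placing 2,4-dimethylphenyl on the ring nitrogen lowers the number. Compound 3 `CC(C)[C@@H]1CC[C@@H](C)C[C@@]12N(C)C(=O)[C@@H]1[C@H]3C(=O)N(c4ccc5ccccc5c4)C(=O)[C@H]3ON12` differs from compound 2 by naphthalen-2-yl in place of 2,4-dimethylphenyl on an amide-type nitrogen in a ring. Going by the values given here, no measured step exchanges one such group for another; the only step that bears on it is a 3.6-fold lower number from compound 1 to compound 2 (0.55 log units; beyond the scatter), which concerns adding such a group at all. Swapping one for another is therefore expected to give a 1.2-fold lower number from compound 2 to compound 3 (0.08 log units; within the scatter), a change inside the scatter. Compound 3 is estimated at 350 ug/mL, within 150 ug/mL to 900 ug/mL.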

Compound 3, half-maximal inhibitory concentration: 2520 ug/mL
Estimate against measurement, compound 3: 7.2-fold (0.86 log units) below; measured number above the stated range.
By their numbers in this assay, from the lowest: compound 2; then compounds 1 and 3 (each within the scatter of the next).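

In this assay, the identity of the group on the amide-type nitrogen in a ring matters, not only its presence: naphthalen-2-yl in place of 2,4-dimethylphenyl gives a 6.0-fold higher number from compound 2 to compound 3 (0.78 log units; beyond the scatter). With naphthalen-2-yl in place of hydrogen, the step is a 1.7-fold higher number from compound 1 to compound 3 (0.23 log units; within the scatter), so an aromatic group on this nitrogen does not by itself lower the number.

Nothing available explains the difference between these two groups. On these data alone, whether phenyl, benzyl or a phenyl ring carrying a carboxylic acid at this nitrogen would give a number like that of compound 2 or that of compound 3 remains open.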